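A few compounds are considered here, and "the series" means these few. Any claim that something is new, unique, unknown or untested is made for them only; others in the source may bear on it.

Measured compounds:
- Compound 1 `N#CC1=C(N)Oc2c(c3nc4ccccc4nc3c3ccccc23)C12C(=O)N(Cc1cnnn1-c1ccccc1Br)c1ccccc12`: in a functional assay on A549 cells (Homo sapiens) for antiproliferative activity, read by MTT assay, with a stated time of 48 h (on this read-out lower numbers stand for stronger inhibition and higher numbers for weaker inhibition), compound 1 gives > 50000 nM, a limit of the assay rather than a number.
- Compound 2 `COc1ccc(-n2nncc2CN2C(=O)C3(C(C#N)=C(N)Oc4c3c3nc5ccccc5nc3c3ccccc43)c3ccccc32)cc1`: compound 2 gives > 50000 nM, again only a limit.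
- Compound 3 `N#CC1=C(N)Oc2c(c3nc4ccccc4nc3c3ccccc23)C12C(=O)N(Cc1cnnn1-c1cccc(S(N)(=O)=O)c1)c1ccccc12`: compound 3 gives 44200 nM.

Compound 2 sits at the limit of > 50000 nM in this assay, at which 2 of the 3 values shown sit, so no actual number is known for it. Compound 4 `Cc1ccc(-n2nncc2CN2C(=O)C3(C(C#N)=C(N)Oc4c3c3nc5ccccc5nc3c3ccccc43)c3ccccc32)cc1C` is the next compound to be tested, and its change from compound 2 is:
3,4-dimethylphenyl in place of 4-methoxyphenyl on an aromatic nitrogen

For the measured compounds named here, no measured step swaps in a 3,4-dimethylphenyl, so the guidance is indirect. Going by the values given here, the step that the two limits leave unreadable from compound 1 to compound 2 shows only that both compounds reach the limit. The steps of an at least 1.1-fold lower number from compound 2 to compound 3 (0.05 log units; that floor lies within the scatter) and an at least 1.1-fold lower number from compound 1 to compound 3 (0.05 log units; that floor lies within the scatter) are each within the scatter, meaning that changing the group on the aromatic nitrogen from 2-bromophenyl to 4-methoxyphenyl or to 3-sulfamoylphenyl moved the read-out little, if at all. The expected step is therefore a number no higher from compound 2 to compound 4 (the limit leaves the size open), none beyond the scatter. Compound 4 is estimated at 50000 nM in this assay, with a range from 30000 nM to 100000 nM, most likely reported as a limit again.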

Compound 4, half-maximal inhibitory concentration: > 50000 nM
Compound 4: no number, only a limit; the forecaster's own chance of this, stated with the estimate: 70%; the middle value lies on the limit itself.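

Replacing 4-methoxyphenyl with 3,4-dimethylphenyl keeps the heavy-atom count but removes the oxygen, the only hydrogen-bond acceptor in that group, and in this assay compound 4 gives > 50000 nM, a limit and not a number. The steps joining compound 1, compound 2 and compound 4 cannot be read, as each of these compounds has only a limit. The one readable step is an at least 1.1-fold higher number from compound 3 to compound 4 (0.05 log units; that floor lies within the scatter), so a fourth substituted phenyl group on this aromatic nitrogen still leaves the values together at one end of the scale: the limit of > 50000 nM in this assay, at which 3 of the 4 values shown sit.

Going by these compounds, all four compounds carry a substituted phenyl group at this position, so it remains open whether a longer chain ending in an amine or a carboxylic acid would lower the number. On these data alone, how far the true values of compound 1, compound 2 and compound 4 lie beyond the limit also remains open.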